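This account rests on a few compounds, and the source may have more. Where it says the series, first, only, none or still open, it means among the compounds named here.

Compound 1 `C=CCOC(=O)c1ccsc1NC(=O)[C@@H]1CCCN1`: in a functional assay on HeLa cells (Homo sapiens) for inhibition (on this read-out higher numbers stand for weaker inhibition of growth and lower numbers for stronger inhibition of growth), compound 1 gives 94.9 ug/mL.
Compound 2 `O=C1CC[C@@H](COC(=O)c2ccsc2NC(=O)[C@@H]2CCCN2)N1`: in this assay compound 2 gives 191 ug/mL.

Among the compounds with values here, compound 1 stands side by side with compound 2 on these numbers, since the only measured step, a 2.0-fold higher number from compound 1 to compound 2 (0.30 log units; within the scatter), lies within the scatter. Compound 3 `CCOC(=O)c1ccsc1NC(=O)[C@@H]1CCCN1` differs from compound 1 in one place: methyl in place of vinyl on a saturated chain carbon bound to an oxygen next to a carbonyl group. Within the data shown here, no measured step exchanges vinyl for methyl at that place; the step to compound 2 altered the same place without moving the number beyond the scatter. The expected step is therefore a 1.1-fold higher number from compound 1 to compound 3 (0.02 log units; within the scatter), none beyond the scatter. Compound 3 is estimated at 100 ug/mL, within a range from 45 ug/mL to 220 ug/mL.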

Compound 3, concentration for 50% growth inhibition: 35.3 ug/mL
Compound 3: middle estimate off by 2.8-fold (0.45 log units), on the high side; measured number below the stated range.
By their numbers in this assay, from the lowest: compound 3; then compounds 1 and 2 (each within the scatter of the next).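

In this assay, the place on a saturated chain carbon bound to an oxygen next to a carbonyl group now proves able to move the number: the change to methyl gives a 2.7-fold lower number from compound 1 to compound 3 (0.43 log units; beyond the scatter) and also a 5.4-fold lower number from compound 2 to compound 3 (0.73 log units; beyond the scatter) as a larger step. Compound 1 and compound 2 had not separated, so compound 3 alone stands apart, though by modest steps. No evidence available here explains this difference.

Going by these compounds, whether a longer chain such as propyl would fall near compound 3 or compound 1 remains open. So does the effect of an amine or a carboxylic acid at this place.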